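The source may report more compounds than this note shows. Statements on the series, on what has been measured and on what is new or still open speak of the compounds shown alone.

Compound 1 `CCOC(=O)c1c(C)coc1-c1ccc2c(CC)cccc2c1OC`: 1.8 ug/mL
Compound 2 `CCCOC(=O)c1c(C)coc1-c1ccc2c(CC)cccc2c1OC`: > 10 ug/mL
Compound 3 `CCc1cccc2c(OC)c(-c3occ(C)c3C(=S)OC)ccc12`: 5.1 ug/mL

Three compounds sharing one core were tested in a functional assay on KBVIN cells (Homo sapiens) for cytotoxicity, read by MTT assay, with a stated time of 72 h; a higher number here means that more compound is needed for the effect, a lower number that less compound is needed. Compound 1 gives 1.8 ug/mL. For compound 2 this assay reports only a limit, > 10 ug/mL. Compound 3 gives 5.1 ug/mL, the highest of the two plain numbers; its nearest neighbour is compound 1, and the step is a 2.8-fold higher number from compound 1 to compound 3 (0.45 log units; beyond the scatter). Lengthening the ester chain gave an at least 5.5-fold higher number from compound 1 to compound 2 (0.74 log units; beyond the scatter), so that compound 2 sits at the limit of > 10 ug/mL in this assay, at which 1 of the 3 values shown sits.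

Compound 4 `CCc1cccc2c(OC)c(-c3occ(C)c3C(=O)NC)ccc12` has not yet been measured. It differs from compound 3 by a group of 4 heavy atoms (2 carbon, 1 nitrogen, 1 oxygen; no ring) in place of a group of 4 heavy atoms (2 carbon, 1 oxygen, 1 sulfur; no ring), on an aromatic carbon. The two steps that touch this same position are a 2.8-fold higher number from compound 1 to compound 3 (0.45 log units; beyond the scatter) and an at least 1.9-fold lower number from compound 2 to compound 3 (0.29 log units; that floor lies within the scatter); both are modest, and the second has only a floor that lies within the scatter. Exchanges at this position have therefore moved the number by modest amounts in this assay, with no measured case of a methylcarbamoyl group. Compound 4 is expected to give 8 ug/mL, with a likely range from 3 ug/mL to 20 ug/mL. This expectation corresponds to a 1.6-fold higher number from compound 3 to compound 4 (0.20 log units; within the scatter), a step that is estimated to be of modest size or within the scatter.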

Compound 4, concentration for half-maximal effect: > 10 ug/mL
Compound 4 ended at the assay's limit; the forecaster's own chance of this, stated with the estimate: 35%; at least 1.2-fold (0.09 log units) between middle value and limit.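

Exchanging ethoxy for methylamino on the carbonyl carbon gave an at least 5.5-fold higher number from compound 1 to compound 4 (0.74 log units; beyond the scatter) in this assay, which shows that this position, on an aromatic carbon of a five-membered aromatic ring with 1 oxygen, can also respond to a methylcarbamoyl group, with its 1 hydrogen-bond donor, and not only to changes among groups without one. Set against the group with 0 hydrogen-bond donors that it replaces, methylcarbamoyl gave an at least 1.9-fold higher number from compound 3 to compound 4 (0.29 log units; that floor lies within the scatter), and since that floor lies within the scatter, this pair alone does not establish a separation. The value of compound 4 is only a limit, the step between compound 2 and compound 4 cannot be read, and the series now has two compounds at the same limit: the limit of > 10 ug/mL in this assay, at which 2 of the 4 values shown sit.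

The compounds shown leave open how a carboxylic acid, a primary amide or a dimethylamide on this carbonyl carbon would read in this assay. On these data alone, a dimethylamide, which has no amide hydrogen, would bear on whether that hydrogen matters, and how far compound 4 lies past its limit also remains open.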